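A Methyl Added to the Chain on Aromatic Nitrogen

The compounds below may be only part of what the source reports. "The series", "measured", "known", "first", "only" and "open" are said of these compounds alone.

Of the compounds shown here, two sharing one core have been measured in an assay on isolated protein for positive allosteric modulation of Neuronal acetylcholine receptor; alpha4/beta2 (Homo sapiens); on this read-out lower numbers stand for an effect already at smaller amounts and higher numbers for an effect only at larger amounts of compound. Compound 1 `Fc1cccc(Cl)c1-c1cc(-c2cnn(C3CCNCC3)c2)on1` gives 48 nM in this assay. Compound 2 `Cn1c(-c2cc(-c3c(F)cccc3Cl)no2)cnc1C1CCNCC1` gives 12 nM in this assay, the lower of the two numbers, and its gap to compound 1 lies beyond the usual scatter. Compound 3 `CCn1c(-c2cc(-c3c(F)cccc3Cl)no2)cnc1C1CCNCC1` has not yet been measured. It differs from compound 2 in one place: methyl in place of hydrogen on a saturated chain carbon bound to an aromatic nitrogen; cut one bond further out, the same difference reads methyl to ethyl. Going by the values given here, no step of this kind between measured compounds is available, so the expected size of the step rests only on the smallness of the change: no shift beyond the scatter is expected in either direction, though a slight drift toward higher numbers cannot be ruled out. Compound 3 is therefore estimated to give about 18 nM in this assay, within a range from 6 nM to 55 nM. This estimate corresponds to an expected step of a 1.5-fold higher number from compound 2 to compound 3 (0.18 log units; within the scatter) in this assay.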

Compound 3, half-maximal effective concentration: 3 nM
For compound 3 the middle estimate is 6.0-fold (0.78 log units) above the measured one; the measured number lies below the stated range.
By their numbers in this assay, from the lowest: compound 3; then compound 2; then compound 1.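

In this assay, methyl in place of hydrogen on a saturated chain carbon bound to an aromatic nitrogen gives a 4.0-fold lower number from compound 2 to compound 3 (0.60 log units; beyond the scatter) and so moves the number beyond the usual scatter. Going by these compounds alone, this position therefore responds to the addition of a single carbon, which the earlier compounds could not show, as no step of this kind was available among them. Read one bond further out, the change from methyl to ethyl goes with a lower number in this assay and not with a higher one, and nothing at hand explains the step.

Going by these compounds, whether the number in this assay keeps falling with a longer chain such as propyl remains open. Also open, on these data alone, is how an isopropyl, a cyclopropyl or a methoxyethyl group in place of the ethyl would compare with compound 3.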